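Three Level Antagonists and an Untested Fourth

The source may hold more compounds than are shown below. What is called first, only, known or untested is meant among the compounds shown, and "the series" means these compounds.

Measured compounds:
compound 1 `O=C(O)Cc1sc(C(c2ccc(F)cc2)c2ccc(F)cc2)nc1-c1ccoc1` — 80%
compound 2 `COc1ccc(OC)c(-c2nc(C(c3ccccc3)c3ccccc3)sc2CC(=O)O)c1` — 80%
compound 3 `O=C(O)Cc1sc(C(c2ccccc2)c2ccc(Cl)cc2)nc1-c1ccc(Cl)cc1` — 80%

Of the compounds shown here, three sharing one core have been tested in an in vitro functional assay on HEK285-7 cells for antagonist activity at prostaglandin D2 receptor 2 (Homo sapiens), read by BRET and beta-arrestin recruitment; on this read-out lower numbers stand for smaller maximal responses and higher numbers for larger maximal responses. Compound 1 reaches 80% there. On these numbers compound 1 stands level with compound 2 and compound 3 at the digits reported: its nearest neighbour is compound 2, with no change within the scatter, and its furthest is compound 3, again with no change within the scatter. Nothing in this set therefore separates the three at the level of maximal response; the various aryl groups at the two ends of the core all give the same plateau.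

Compound 4 `Cc1cc(-c2nc(C(c3ccc(F)cc3)c3ccc(F)cc3)sc2CC(=O)O)cnc1N` has not yet been measured in this assay. It differs from compound 1 in one place: 6-amino-5-methylpyridin-3-yl in place of furan-3-yl on an aromatic carbon. Within the data shown here, no measured pair shows what such a change does to the maximal response, so the only guide is that three quite different aromatic groups at this position all reached the same plateau. On that basis no step beyond the scatter is expected in this assay, in either direction. Compound 4 is accordingly estimated to give 80%, with a range from 62% to 95%. The expected step is no change at the digits printed from compound 1 to compound 4 (within the scatter).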

Compound 4, largest response reached (reported as efficacy), in percent of the reference or control that the assay uses: 80%
Compound 4: middle estimate and measured number agree at the digits printed; low and high end bracket the measured number.
By their numbers in this assay, from the lowest: compounds 1, 2, 3 and 4 (each within the scatter of the next).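

In this assay, among these compounds, putting 6-amino-5-methylpyridin-3-yl in place of furan-3-yl gives no change at the digits printed from compound 1 to compound 4 (within the scatter) and provides the only measured pair in this set that differs in one place. At this aromatic carbon, next to the ring nitrogen and next to the ring atom that bears a carboxymethyl group, a six-membered aromatic ring can therefore replace a five-membered one without a step beyond the scatter in maximal response. The same holds for this exchange with its added hydrogen-bond donor and additional hydrogen-bond acceptor, although nothing shown here bears on why the maximal response is held.

The compounds shown leave open whether a saturated ring such as piperidine, or a chain ending in an amine or a carboxylic acid, would hold the same response at this carbon in this assay. They also leave open whether the pyridine ring would behave alike with only its amino group or only its methyl group, and whether the exchange would give the same result with a different large group on the ring.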